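The compounds below may be only part of what the source reports. "The series", "measured", "known", "first", "only" and "open" are said of these compounds alone.

Measured in a physicochemical assay for solubility, read by LC-MS, in phosphate buffer, with a stated time of 24 h, at pH 7.4; on this read-out higher numbers stand for higher solubility and lower numbers for lower solubility:
- compound 1 `Cn1nccc1-c1cnc(NCc2c(F)ccc3c2CCO3)c2cn[nH]c(=O)c12`: 2000 nM
- compound 2 `C[C@@H]1CC(=O)N(c2cnc(NCc3c(F)ccc4c3CCO4)n3cnnc23)C1`: 130000 nM
- compound 3 `COCCC(=O)Nc1cnc(NCc2c(F)ccc3c2CCO3)n2cnnc12`: 980000 nM

Compound 1 has the lowest of these three numbers, and compound 2 and compound 3 are built on a different core. Compound 4 `CC(=O)N1CCC(c2cnc(NCc3c(F)ccc4c3CCO4)c3cn[nH]c(=O)c23)CC1` keeps the core of compound 1 and changes one group on an aromatic carbon: 1-acetylpiperidin-4-yl in place of 1-methyl-1H-pyrazol-5-yl on an aromatic carbon. Among the compounds with values here, no measured step makes this exact swap. The nearest guide is a 7.5-fold higher number from compound 2 to compound 3 (0.88 log units; beyond the scatter), a modest rise, where ((2-methoxyethyl)carbonyl)amino enters in place of 4-methyl-2-oxopyrrolidin-1-yl. It involves other groups on another core, so it is weak evidence. A rise of somewhat smaller size is therefore expected, and the estimated change is a 4.0-fold higher number from compound 1 to compound 4 (0.60 log units; beyond the scatter). Compound 4 is estimated at 8000 nM, with an expected range of 2000 nM to 40000 nM.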

Compound 4, solubility: < 2000 nM
Compound 4: only a limit was reported (the forecaster's own chance of this, stated with the estimate: 5%); middle value at least 4.0-fold (0.60 log units) from the limit.
By their numbers in this assay, from the lowest: compound 1; then compound 2; then compound 3.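

In this assay, putting 1-acetylpiperidin-4-yl in place of 1-methyl-1H-pyrazol-5-yl gives a number no higher from compound 1 to compound 4 (the limit leaves the size open). Compound 4 carries only a limit, so the size of this step cannot be read: the limit of < 2000 nM in this assay, at which 1 of the 4 values shown sits. Even so, this first change shown on the core of compound 1 brings no rise, so the rise seen on the other core does not carry over to this swap.

Still open, going by these compounds, is how far compound 4 lies under its limit. Also open, on these data alone, is whether a free amine or a carboxylic acid at this position would raise the number.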